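Swapping the Urea Aryl Group for a Chromone Amide

The source may hold more compounds than are shown below. What is called first, only, known or untested is meant among the compounds shown, and "the series" means these compounds.

Measured compounds:
compound 1 `COc1cc(Nc2ncnc3c(NC(=O)Nc4ccc(F)cc4C(F)(F)F)cccc23)cc(OC)c1` gives 2970 nM in a functional assay on RT-112 cells (Homo sapiens) for antiproliferative activity, read by MTT assay, with a stated time of 72 h; on this read-out higher numbers stand for weaker inhibition of growth and lower numbers for stronger inhibition of growth
compound 2 `COc1cc(Nc2ncnc3c(NC(=O)Nc4cccc(Cc5ccccc5)c4)cccc23)cc(OC)c1` gives 1740 nM in this assay

Compound 1 holds the highest of the two numbers, but compound 2 lies within the scatter of it, so the two cannot be ranked. Compound 3 `COc1cc(Nc2ncnc3c(NC(=O)c4cc(=O)c5ccccc5o4)cccc23)cc(OC)c1` is not yet measured. Compared with compound 1 it carries a group of 11 heavy atoms (9 carbon, 2 oxygen; one six-membered aromatic ring of carbon only, one six-membered aromatic ring with 1 hetero atom) in place of a group of 12 heavy atoms (7 carbon, 1 nitrogen, 4 fluorine; one six-membered aromatic ring of carbon only), on a carbonyl carbon. The shared core is unchanged. Among the compounds with values here, no measured pair shows this kind of change, so the expected step of a 1.3-fold higher number from compound 1 to compound 3 (0.13 log units; within the scatter) is small, with a wide range in either direction. Compound 3 is therefore estimated at 4000 nM, between 1000 nM and 16000 nM.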

Compound 3, concentration for 50% growth inhibition: > 20000 nM
Compound 3: a limit, no number; the forecaster's own chance of this, stated with the estimate: 15%; middle value at least 5.0-fold (0.69 log units) from the limit.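

Within the data shown here, compound 1 and compound 2 could not be ranked, but this change gives the first readable step at this position: in this assay, putting the chromone group on the carbonyl carbon gives an at least 6.7-fold higher number from compound 1 to compound 3 (0.82 log units; beyond the scatter). Compound 3 gives > 20000 nM, which is a limit of the assay and not a number. The group on this carbonyl carbon therefore matters for growth inhibition, at least in this one swap.

This swap replaces the urea with an amide and changes the aryl group in a single step, so the two changes cannot be separated. As far as these compounds go, it remains open how an amide carrying a plain phenyl or a pyridine ring would behave.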